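This account rests on a few compounds, and the source may have more. Where it says the series, first, only, none or still open, it means among the compounds named here.

In an ADME assay on microsomes from liver (Homo sapiens) for metabolic stability (a higher number here means faster removal of the compound, a lower number slower removal), compound 3 `O=C(N[C@H]1CN(S(=O)(=O)c2ccccc2)C[C@@H]1C(=O)N[C@H]1CCCNC1)c1nnc(-c2ccc(F)cc2)s1` gives 8.8 mL.min-1.g-1 and compound 1 `Cc1csc(C(=O)N[C@H]2CN(S(=O)(=O)c3ccccc3)C[C@@H]2C(=O)N[C@H]2CCCNC2)n1` gives 9.1 mL.min-1.g-1, so the two sit level: a 1.0-fold lower number from compound 1 to compound 3 (0.01 log units; within the scatter). Compound 2 `O=C(N[C@H]1CN(S(=O)(=O)c2ccccc2)C[C@@H]1C(=O)N[C@H]1CCCNC1)c1cn(C2CC2)cn1` is reported only as a limit, < 3 mL.min-1.g-1. Measured against that limit, the swaps at this carbonyl carbon are an at least 3.0-fold lower number from compound 1 to compound 2 (0.48 log units; beyond the scatter) and an at least 2.9-fold higher number from compound 2 to compound 3 (0.46 log units; beyond the scatter). Compound 4 `O=C(N[C@H]1CN(S(=O)(=O)c2ccccc2)C[C@@H]1C(=O)N[C@H]1CCCNC1)c1cc(-c2ccc(Cl)cc2)on1` changes the same place again: a group of 12 heavy atoms (9 carbon, 1 nitrogen, 1 oxygen, 1 chlorine; one five-membered aromatic ring with 2 hetero atoms, one six-membered aromatic ring of carbon only) in place of a group of 12 heavy atoms (8 carbon, 2 nitrogen, 1 fluorine, 1 sulfur; one five-membered aromatic ring with 3 hetero atoms, one six-membered aromatic ring of carbon only), on a carbonyl carbon. Its 5-(4-chlorophenyl)-1,2-oxazol-3-yl group pairs a five-membered aromatic ring with a six-membered aromatic ring of carbon only, as the group in compound 3 does. Among the measured compounds shown here, no measured step covers this exact swap, so the closest guide is the flat a 1.0-fold lower number from compound 1 to compound 3 (0.01 log units; within the scatter). In this assay, the expected change is a 1.0-fold higher number from compound 3 to compound 4 (0.01 log units; within the scatter), with nothing beyond the scatter anticipated. The estimate for compound 4 is 9 mL.min-1.g-1, with an expected range from 4.5 mL.min-1.g-1 to 18 mL.min-1.g-1.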

Compound 4, intrinsic clearance in microsomes in the Homo sapiens assay: < 3 mL.min-1.g-1
Compound 4 ended at the assay's limit (the forecaster's own chance of this, stated with the estimate: 10%); middle value at least 3.0-fold (0.47 log units) away from the limit.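

In the Homo sapiens assay, compound 4 is reported only as a limit, < 3 mL.min-1.g-1. In the Homo sapiens assay, two groups that each pair a five-membered aromatic ring with a six-membered aromatic ring of carbon only do not behave alike at this carbonyl carbon: an at least 2.9-fold lower number from compound 3 to compound 4 (0.46 log units; beyond the scatter), and an at least 3.0-fold lower number from compound 1 to compound 4 (0.48 log units; beyond the scatter). The step between compound 2 and compound 4 cannot be read, as both values are limits. In a physicochemical assay for solubility, at pH 7.4 (on this read-out lower numbers stand for lower solubility and higher numbers for higher solubility), compound 3 gives 234000 nM and compound 4 gives 12000 nM. In the physicochemical assay, the same swap comes with a 20-fold lower number from compound 3 to compound 4 (1.29 log units; beyond the scatter).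

Compound 3 and compound 4 differ in both the five-membered ring and the halogen, so neither change can be singled out. Going by these compounds, a 5-(4-fluorophenyl)-1,2-oxazol-3-yl group at this carbonyl carbon would separate the two, and its result remains open.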